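Swapping Methyl for Nitro on the Aryl Ring

A few compounds are considered here, and "the series" means these few. Any claim that something is new, unique, unknown or untested is made for them only; others in the source may bear on it.

Compound 1 `O=C1C=CC(OCC(F)(F)F)N1c1cc(Cl)cc(Cl)c1`: 5920 nM
Compound 2 `Cc1ccc(N2C(=O)C=CC2OCC(F)(F)F)cc1`: 9380 nM

Both compounds were tested in a functional assay on HeLa cells (Homo sapiens) for inhibition (a higher number here means a weaker inhibitor, a lower number a stronger inhibitor), and the two numbers lie within the usual scatter of each other, so the data show no real difference between compound 1 and compound 2. Compound 3 `O=C1C=CC(OCC(F)(F)F)N1c1ccc([N+](=O)[O-])cc1` differs from compound 2 in one place: nitro in place of methyl on an aromatic carbon. For the measured compounds named here, no measured pair shows what such a swap does on this core, so the expected step of a 1.3-fold lower number from compound 2 to compound 3 (0.13 log units; within the scatter) is modest and may not reach beyond the scatter. Compound 3 is therefore estimated at 7000 nM, with a range from 2500 nM to 20000 nM.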

Compound 3, half-maximal inhibitory concentration: 2380 nM
Beside the measured number, compound 3's estimate is 2.9-fold (0.47 log units) above it, outside the stated range (below it).
By their numbers in this assay, from the lowest: compound 3; then compounds 1 and 2 (each within the scatter of the next).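

this assay shows a 3.9-fold lower number from compound 2 to compound 3 (0.60 log units; beyond the scatter) when nitro replaces methyl on this aromatic carbon, para to a large group. The group at this position therefore matters for inhibition, and a single change here can move the number beyond the scatter. No measurement shown explains why this swap has this effect.

For the compounds shown here, with only this one swap to go on, a single step cannot show a trend across groups at this position. As far as these compounds go, whether an amine, a nitrile or a carboxylic acid there would give a lower or a higher number remains open.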